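The compounds below may be only part of what the source reports. "The series", "measured", "known", "first", "only" and "open" are said of these compounds alone.

Measured compounds in a functional assay on the whole organism (B cells) with Mus musculus as the target; a higher number here means a larger maximal response, a lower number a smaller maximal response:
- compound 1 `Nc1nc(O)c2c(n1)n(C1OC(CO)[C@@H](O)[C@H]1O)c(=O)n2C/C=C/c1ccccc1`: 73%
- compound 2 `CCCCCCCCCCn1c(=O)n(C2OC(CO)[C@@H](O)[C@H]2O)c2nc(N)nc(O)c21`: 0%
- compound 3 `CCn1c(=O)n(C2OC(CO)[C@@H](O)[C@H]2O)c2nc(N)nc(O)c21`: 82%

Compound 3 gives the highest of these three numbers, yet its gap to compound 1 lies within the scatter; only compound 2 stands clearly apart, with a number 82 percentage points higher from compound 2 to compound 3 (beyond the scatter).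

Compound 4 `NC(=O)Cn1c(=O)n(C2OC(CO)[C@@H](O)[C@H]2O)c2nc(N)nc(O)c21` differs from compound 3 in one place: carbamoyl in place of methyl on a saturated chain carbon bound to an aromatic nitrogen. The same position has already been varied twice among the measured compounds. Replacing 2-phenylethenyl by methyl gave a number 9 percentage points higher from compound 1 to compound 3 (within the scatter), whereas replacing it by nonyl gave a number 73 percentage points lower from compound 1 to compound 2 (beyond the scatter). So a short or aromatic group at this saturated chain carbon bound to an aromatic nitrogen leaves the maximal response roughly unchanged, while only the long nonyl chain abolished it. Carbamoyl is a short group, closer in size to methyl than to nonyl, so no step beyond the scatter is expected here, and the estimated change is a number 12 percentage points lower from compound 3 to compound 4 (beyond the scatter). For compound 4 the expected value in this assay is therefore 70%, with a range from 35% to 95%.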

Compound 4, largest response reached (reported as maximal response), in percent of the reference or control that the assay uses: 32%
Compound 4: the middle estimate sits 38 percentage points above what was measured; the whole stated range lies above it.
By their numbers in this assay, from the lowest: compound 2; then compound 4; then compounds 1 and 3 (each within the scatter of the next).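

At this saturated chain carbon bound to an aromatic nitrogen, a short group does not by itself preserve the response in this assay: carbamoyl in place of methyl gives a number 50 percentage points lower from compound 3 to compound 4 (beyond the scatter) and carbamoyl in place of 2-phenylethenyl gives a number 41 percentage points lower from compound 1 to compound 4 (beyond the scatter). The response is also not simply all or nothing, since carbamoyl in place of nonyl gives a number 32 percentage points higher from compound 2 to compound 4 (beyond the scatter) and so places carbamoyl at an intermediate level among these groups. Nothing available explains why carbamoyl behaves this way.

The compounds shown leave open which part of carbamoyl goes with the lower response, the carbonyl or the amide hydrogen. A carboxylic acid, a methyl ester or an amine at the same place would help to separate these parts.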